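The source may hold more compounds than are shown below. What is called first, only, known or untested is meant among the compounds shown, and "the series" means these compounds.

Measured compounds in a functional assay, with a stated time of 20 min, tested at 0.5 mg/mL; on this read-out higher numbers stand for a stronger effect at the one concentration tested and lower numbers for a weaker effect:
compound 1 `CC(C)[C@@H]1CC[C@@H](C)C[C@@]12N(C)C(=O)[C@@H]1[C@H]3C(=O)NC(=O)[C@H]3ON12` gives 21.6%;
compound 2 `COc1ccc(N2C(=O)[C@H]3[C@H](ON4[C@@H]3C(=O)N(C)[C@@]43C[C@H](C)CC[C@H]3C(C)C)C2=O)cc1` gives 32.9%;
compound 3 `Cc1ccc(N2C(=O)[C@H]3[C@H](ON4[C@@H]3C(=O)N(C)[C@@]43C[C@H](C)CC[C@H]3C(C)C)C2=O)c(C)c1` gives 49.9%.

Compound 3 stands highest of the three in this assay, with compound 2 nearest and compound 1 furthest; both gaps lie beyond the scatter. Among the measured compounds shown here, the steps so far all concern the same amide-type ring nitrogen: a number 11.3 percentage points higher from compound 1 to compound 2 (beyond the scatter), a number 28.3 percentage points higher from compound 1 to compound 3 (beyond the scatter) and a number 17 percentage points higher from compound 2 to compound 3 (beyond the scatter). Compound 4 `CC(C)[C@@H]1CC[C@@H](C)C[C@@]12N(C)C(=O)[C@@H]1[C@H]3C(=O)N(c4ccc5ccccc5c4)C(=O)[C@H]3ON12` continues from compound 3 by the change (naphthalen-2-yl in place of 2,4-dimethylphenyl on an amide-type nitrogen in a ring). For the measured compounds named here, no measured step covers a naphthalen-2-yl group, so the bearing steps only show that each aryl group on this nitrogen has given a higher number than hydrogen, and that the aryl groups differ among themselves. The step to compound 4 is therefore expected to be small, within the scatter, estimated as a number 2.1 percentage points higher from compound 3 to compound 4 (within the scatter). Compound 4 is estimated at 52%, within 36% to 68%.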

Compound 4, a percentage reported as activity, at one concentration (the size of the read-out at that concentration, not a potency): 13.8%
Compound 4: middle estimate off by 38.2 percentage points, on the high side; the whole stated range lies above it.
By their numbers in this assay, from the lowest: compounds 4 and 1 (each within the scatter of the next); then compound 2; then compound 3.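

In this assay, an aryl group on this amide-type nitrogen no longer always gives a higher number than hydrogen: the naphthalen-2-yl group shows a number 7.8 percentage points lower from compound 1 to compound 4 (within the scatter). Against the other aryl groups it shows a number 36.1 percentage points lower from compound 3 to compound 4 (beyond the scatter) and a number 19.1 percentage points lower from compound 2 to compound 4 (beyond the scatter), so the outcome at this nitrogen depends on which aryl group is present, not merely on an aryl group being there. No available data explain this difference. From the compounds shown here alone, whether a benzyl group, or a phenyl ring carrying an amine or a carboxylic acid, would keep the number of compound 3 remains open. Going by these compounds, the effect of changes elsewhere on the shared core also remains open.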